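A few compounds are considered here, and "the series" means these few. Any claim that something is new, unique, unknown or untested is made for them only; others in the source may bear on it.

compound 1 `COc1ccc2c(=O)c(/C=C/C(=O)NCc3ccccc3)coc2c1`: 376000 nM
compound 2 `COc1ccc2c(=O)c(/C=C/C(=O)NCc3ccc(F)cc3)coc2c1`: 133000 nM

Both values come from an ADME assay on HepG2 2.2.15 cells (Homo sapiens) for cytotoxicity, read by MTT assay, with stated times of 48 h and 9 days; a lower number here means that less compound is tolerated, a higher number that more compound is tolerated. Of the two compounds, compound 2 has the lower number, at 133000 nM. Compound 3 `COc1ccc2c(=O)c(/C=C/C(=O)NCc3ccccc3F)coc2c1` has not yet been measured. It contains the same atoms as compound 2, joined differently: 2-fluorophenyl in place of 4-fluorophenyl on a saturated chain carbon bound to an amide-type nitrogen.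

Going by the values given here, only one measured step bears on this change: a 2.8-fold lower number from compound 1 to compound 2 (0.45 log units; beyond the scatter). It is modest and comes from fluoro in place of hydrogen on an aromatic carbon. Among the compounds with values here, no measured compound yet carries the 2-fluorophenyl group, so the data cannot show directly what this change will do. Compound 3 keeps the fluoro, so a step no larger than the measured one is expected, with at most a slight drift toward the higher number of compound 1. The expected change is small, a 1.4-fold higher number from compound 2 to compound 3 (0.13 log units; within the scatter). Compound 3 is estimated at 180000 nM, with an expected range of 80000 nM to 400000 nM.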

Compound 3, half-maximal cytotoxic concentration: 146000 nM
Compound 3: middle estimate off by 1.2-fold (0.09 log units), on the high side, and the stated range covers the measured number.
By their numbers in this assay, from the lowest: compounds 2 and 3 (each within the scatter of the next); then compound 1.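

Moving the fluoro from 4-fluorophenyl to 2-fluorophenyl, on a saturated chain carbon bound to an amide-type nitrogen, gives a 1.1-fold higher number from compound 2 to compound 3 (0.04 log units; within the scatter) in this assay, so the two placements cannot be told apart in this cytotoxicity read-out. Compared with the unsubstituted compound, the new placement gives a 2.6-fold lower number from compound 1 to compound 3 (0.41 log units; beyond the scatter), and the earlier placement gave a 2.8-fold lower number from compound 1 to compound 2 (0.45 log units; beyond the scatter), so across these three compounds the lower number goes with having a fluoro on this ring, whichever of the two placements it takes, and none of the three goes against this. No measurement here explains why the fluoro compounds are tolerated at lower concentrations than the unsubstituted one, or why the two placements match.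

The compounds shown leave open whether this pattern belongs to fluoro alone or would also hold for a larger group on the same ring, such as chloro, methoxy or trifluoromethyl. They also leave open how the number would respond if the benzyl group gave way to a longer chain between the amide nitrogen and the ring.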